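A chloro for an ethoxy in compound 3

This account rests on a few compounds, and the source may have more. Where it says the series, first, only, none or still open, it means among the compounds named here.

Compound 1 `COc1cc(-n2ncnc2-c2ccc(C)cc2)cc(OC)c1OC` gives 300 nM
Compound 2 `COc1cccc(-c2ncnn2-c2cc(OC)c(OC)c(OC)c2)c1` gives > 10000 nM (a limit)
Compound 3 `CCOc1ccc(-c2ncnn2-c2cc(OC)c(OC)c(OC)c2)cc1Cl` gives 3 nM

In a functional assay on Jurkat cells (Homo sapiens) for antiproliferative activity, read by MTT assay, with a stated time of 72 h (on this read-out higher numbers stand for weaker inhibition and lower numbers for stronger inhibition), compound 3 gives 3 nM, the lower of the two numbers, beyond the scatter from compound 1 . Compound 4 `COc1cc(-n2ncnc2-c2ccc(Cl)c(Cl)c2)cc(OC)c1OC` differs from compound 3 by chloro in place of ethoxy on an aromatic carbon, with chloro in place of ethoxy on an aromatic carbon. Going by the values given here, the only measured step is an at least 33-fold higher number from compound 1 to compound 2 (1.52 log units; beyond the scatter). It is large, but it concerns a different replacement, so it serves only as a rough guide to size. With that step in mind, a large rise in the number is expected, meaning weaker inhibition. The expected change is a 67-fold higher number from compound 3 to compound 4 (1.82 log units; beyond the scatter), beyond the scatter. For compound 4 the estimate is 200 nM, with an expected range from 20 nM to 3000 nM.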

Compound 4, half-maximal inhibitory concentration: > 10000 nM
Compound 4 ended at the assay's limit; the forecaster's own chance of this, stated with the estimate: 10%; middle value at least 50-fold (1.69 log units) away from the limit.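

With the ethoxy group of compound 3 replaced by chloro, ortho to a chloro group, this assay shows an at least 3300-fold higher number from compound 3 to compound 4 (3.52 log units; beyond the scatter), so activity at this position depends strongly on which group is present. The 3,4-dichlorophenyl group also compares poorly with the 4-methylphenyl group, with an at least 33-fold higher number from compound 1 to compound 4 (1.52 log units; beyond the scatter). The step from compound 2 to compound 4 cannot be read, since both compounds give a limit and not a number: the limit of > 10000 nM in this assay, at which 2 of the 4 values shown sit.

The compounds shown leave open whether a longer chain, such as butoxy, or an amine at this place would retain the activity of compound 3. They also leave open how much weaker compound 4 is than its limit shows.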